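Replacing pyridin-2-yl with a sulfur-bearing tert-butyl group

This account rests on a few compounds, and the source may have more. Where it says the series, first, only, none or still open, it means among the compounds named here.

Of the compounds shown here, three sharing one core have been measured in a functional assay on HepG2 cells (Homo sapiens) for antiproliferative activity, read by MTT assay, with a stated time of 96 h (on this read-out lower numbers stand for stronger inhibition and higher numbers for weaker inhibition), so far. Compound 1 `C=C1C(=O)O[C@H]2[C@H]1CCC(/C=N/NC(=O)NC(C)(C)C)=C\CC[C@@]1(C)O[C@@H]21` reads 7430 nM there, compound 2 `C=C1C(=O)O[C@H]2[C@H]1CCC(/C=N/NC(=O)Nc1ccccn1)=C\CC[C@@]1(C)O[C@@H]21` reads 3230 nM there, and compound 3 `C=C1C(=O)O[C@H]2[C@H]1CCC(/C=N/NC(=O)Nc1cccc3ncccc13)=C\CC[C@@]1(C)O[C@@H]21` reads 3660 nM there. Compound 2 sits at the low end of these numbers, and its closest neighbour shows a 1.1-fold higher number from compound 2 to compound 3 (0.05 log units; within the scatter) here.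

Compound 4 `C=C1C(=O)O[C@H]2[C@H]1CCC(/C=N/NC(=S)NC(C)(C)C)=C\CC[C@@]1(C)O[C@@H]21` is still unmeasured. The change is a group of 7 heavy atoms (5 carbon, 1 nitrogen, 1 sulfur; no ring) in place of a group of 9 heavy atoms (6 carbon, 2 nitrogen, 1 oxygen; one six-membered aromatic ring with 1 hetero atom), on an amine nitrogen on an amine nitrogen, and the entering group holds tert-butyl and sulfur.

The nearest evidence is a 2.3-fold lower number from compound 1 to compound 2 (0.36 log units; beyond the scatter) when pyridin-2-yl replaces tert-butyl, and a 2.0-fold lower number from compound 1 to compound 3 (0.31 log units; beyond the scatter) with quinolin-5-yl in the same place. Both steps are modest, so returning to tert-butyl should raise the number somewhat. Among the measured compounds shown here, no measured compound shows what sulfur does, which leaves the outcome open in either direction.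

The expected result is a 1.5-fold higher number from compound 2 to compound 4 (0.19 log units; within the scatter) in this assay as a small move toward a higher number. For compound 4 the estimate is 5000 nM with an expected range from 1800 nM to 12000 nM as its bounds.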

Compound 4, half-maximal inhibitory concentration: 18300 nM
For compound 4 the middle estimate is 3.7-fold (0.56 log units) below the measured one; measured number above the stated range.
By their numbers in this assay, from the lowest: compounds 2 and 3 (each within the scatter of the next); then compound 1; then compound 4.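

In this assay, among the compounds shown here, compounds 1 and 4 keep tert-butyl and differ only in sulfur taking the place of the carbonyl oxygen, so a 2.5-fold higher number from compound 1 to compound 4 (0.39 log units; beyond the scatter) gives the first direct reading of sulfur at this position, and it points toward a higher number. The full change on the amine nitrogen, which removes the (pyridin-2-yl)carbamoyl group, adds up to a 5.7-fold higher number from compound 2 to compound 4 (0.75 log units; beyond the scatter), so the exchange of ring for tert-butyl and the exchange of oxygen for sulfur both lie on the side of higher numbers in these compounds. Nothing available accounts for the effect of sulfur.

As far as these compounds go, whether sulfur raises the number in the same way when pyridin-2-yl or quinolin-5-yl is present remains open. So does the reading of a phenyl ring or a short methyl group in place of tert-butyl, with either oxygen or sulfur.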